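Urea aryl swap in a series of growth inhibitors

The source may report more compounds than this note shows. Statements on the series, on what has been measured and on what is new or still open speak of the compounds shown alone.

Compound 1, `O=C(Nc1cccc(-n2cc(-c3ccncc3)c(-c3ccc(Cl)c(O)c3)n2)c1)Nc1cccc(C(F)(F)F)c1`, gives only a limit of > 32500 nM in a functional assay on Hs-578T cells (Homo sapiens) for inhibition, read by sulforhodamine B assay, with a stated time of 48 h; on this read-out lower numbers stand for stronger inhibition of growth and higher numbers for weaker inhibition of growth.
Compound 2, `COc1cc(-c2nn(-c3cccc(NC(=O)c4cccc(C(F)(F)F)c4)c3)cc2-c2ccncc2)ccc1Cl`, gives only a limit of > 50000 nM in this assay.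
Compound 3, `COc1cc(-c2nn(-c3cccc(NC(=O)Nc4ccc(Cl)c(Cl)c4)c3)cc2-c2ccncc2)ccc1Cl`, gives only a limit of > 50000 nM in this assay.

Compound 3 thus stands at a limit rather than at a number in this assay, and the two other values shown are limits as well (the limit of > 32500 nM in this assay, at which 1 of the 3 values shown sits, (the limit of > 50000 nM in this assay, at which 2 of the 3 values shown sit)). Compound 4, `COc1cc(-c2nn(-c3cccc(NC(=O)Nc4cccc(C(F)(F)F)c4)c3)cc2-c2ccncc2)ccc1Cl`, differs from compound 3 by 3-(trifluoromethyl)phenyl in place of 3,4-dichlorophenyl on an amide-type nitrogen. A single measured step touches this change, a step that the two limits leave unreadable from compound 2 to compound 3, and its two limits leave its size unreadable. Compound 1 carries the same trifluoromethylphenyl urea as compound 4, with hydroxy in place of methoxy, and it too reaches only a limit. Nothing shown therefore points to a step beyond the scatter in either direction, and compound 4 is expected to sit at a limit like its neighbours. In this assay compound 4 is estimated at 60000 nM, with a range from 25000 nM to 150000 nM. The step from compound 3 to compound 4 is accordingly estimated at a step that the limit leaves unreadable from compound 3 to compound 4.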

Compound 4, concentration for total growth inhibition: 12500 nM
Beside the measured number, compound 4's estimate is 4.8-fold (0.68 log units) above it; the measured number lies below the stated range.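

Of the four compounds, only compound 4 gives a number rather than a limit in this assay, which shows that growth inhibition responds to the group on this amide-type nitrogen: 3-(trifluoromethyl)phenyl in place of 3,4-dichlorophenyl gives an at least 4.0-fold lower number from compound 3 to compound 4 (0.60 log units; beyond the scatter). The urea link and the group on the oxygen also matter when the 3-(trifluoromethyl)phenyl is kept, since (3-(trifluoromethyl)phenyl)amino in place of 3-(trifluoromethyl)phenyl on a carbonyl carbon gives an at least 4.0-fold lower number from compound 2 to compound 4 (0.60 log units; beyond the scatter), and methyl in place of hydrogen on an oxygen on an aromatic ring gives an at least 2.6-fold lower number from compound 1 to compound 4 (0.41 log units; beyond the scatter). Nothing shown gives a cause for these steps.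

On these data alone, the full size of each step stays open, as each starts from a limit. Also open, as far as these compounds go, is whether the trifluoromethyl itself is needed, or whether a nitrile or a carboxylic acid in its place would serve.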